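The source may hold more compounds than are shown below. What is called first, only, known or untested is meant among the compounds shown, and "the series" means these compounds.

Compound 1 `CCCCCCCN(CCCCCSc1nc(N)c2c[nH]nc2n1)C(=O)Nc1ccc(F)cc1F`: 72500 nM
Compound 2 `CCCCCCCN(CCCCCSc1[nH]cnc2ncnc1-2)C(=O)Nc1ccc(F)cc1F`: 5320 nM

Among the compounds with values here, in an assay on cells (Macrophage) for inhibition of sterol O-acyltransferase 1 (Mus musculus) (on this read-out higher numbers stand for weaker inhibition and lower numbers for stronger inhibition), compound 2 gives the lower of the two numbers, and its only neighbour is compound 1; the step of a 14-fold lower number from compound 1 to compound 2 (1.13 log units; beyond the scatter) lies beyond the scatter. That step exchanges the bicyclic group on the sulfur and leaves the urea end of the molecule untouched.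

Compound 3 `CCCCCCCN(CCCCCSc1[nH]cnc2ncnc1-2)C(=O)NC(C)C` differs from compound 2 at that urea end: isopropyl in place of 2,4-difluorophenyl on an amide-type nitrogen. Within the data shown here, no measured step bears on this position. Among the measured compounds shown here, the single measured step, a 14-fold lower number from compound 1 to compound 2 (1.13 log units; beyond the scatter), concerns the sulfur-linked group and gives no guide to a change on the amide-type nitrogen. The expectation for compound 3 in this assay therefore rests on the value of compound 2 alone and carries a wide range. Compound 3 is expected at 8000 nM, between 1500 nM and 40000 nM. The step of a 1.5-fold higher number from compound 2 to compound 3 (0.18 log units; within the scatter) is estimated to remain within the scatter, with the uncertainty acknowledged as large.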

Compound 3, half-maximal inhibitory concentration: 4720 nM
Beside the measured number, compound 3's estimate is 1.7-fold (0.23 log units) above it, and the stated range covers the measured number.
By their numbers in this assay, from the lowest: compounds 3 and 2 (each within the scatter of the next); then compound 1.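

On the amide-type nitrogen, the urea end now has its first reading in this assay: isopropyl in place of 2,4-difluorophenyl gives a 1.1-fold lower number from compound 2 to compound 3 (0.05 log units; within the scatter) and so leaves the read-out within the scatter. With this sulfur-linked group, neither the aromatic ring nor the two fluorines are needed to hold this level of inhibition, and the smaller isopropyl serves as well as 2,4-difluorophenyl. No measurement at hand explains this outcome.

As far as these compounds go, it remains open whether other groups on this nitrogen, such as a cyclohexyl ring, a longer chain or a carboxylic acid, would read the same. Also open, from the compounds shown here alone, is whether isopropyl would behave the same way alongside the sulfur-linked group of compound 1.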